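The compounds below may be only part of what the source reports. "The series", "measured", "known", "first", "only" and "open" are said of these compounds alone.

Compound 2 `Cn1ccnc1NC(=O)c1cccc(Nc2ncc(F)c(Nc3ccc(F)cc3)n2)c1` and compound 1 `COc1ccc(NC(=O)c2cccc(Nc3ncc(F)c(Nc4ccc(F)cc4)n3)c2)cc1` share the same core and differ only in the group carried on the amide-type nitrogen. In a functional assay on A549 cells (Homo sapiens) for antiproliferative activity, read by sulforhodamine B assay, with a stated time of 3 days (on this read-out lower numbers stand for stronger inhibition of growth and higher numbers for weaker inhibition of growth), compound 1 gives 11000 nM, and compound 2 gives 10100 nM. Compound 2 thus holds the lowest of the two numbers shown, but the step of a 1.1-fold lower number from compound 1 to compound 2 (0.04 log units; within the scatter) falls within the scatter, so the two cannot really be told apart. Compound 3 `O=C(NCCO)c1cccc(Nc2ncc(F)c(Nc3ccc(F)cc3)n2)c1` carries a further change at the same place: 2-hydroxyethyl in place of 1-methyl-1H-imidazol-2-yl on an amide-type nitrogen. Among the measured compounds shown here, the only measured step that bears on this change, a 1.1-fold lower number from compound 1 to compound 2 (0.04 log units; within the scatter), shows that exchanging one group for another on this nitrogen left the number essentially where it was, so no movement beyond the scatter is expected here either, and the step of a 1.2-fold higher number from compound 2 to compound 3 (0.07 log units; within the scatter) is the expected outcome. Compound 3 is therefore estimated to give 12000 nM in this assay, with a likely range from 5000 nM to 30000 nM.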

Compound 3, concentration for 50% growth inhibition: 11900 nM
Compound 3: middle estimate off by 1.0-fold (0.00 log units), on the high side, and the stated range covers the measured number.
By their numbers in this assay, from the lowest: compounds 2, 1 and 3 (each within the scatter of the next).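

In this assay, the step of a 1.2-fold higher number from compound 2 to compound 3 (0.07 log units; within the scatter) and the step of a 1.1-fold higher number from compound 1 to compound 3 (0.03 log units; within the scatter) both lie within the scatter, so compound 3 cannot be told apart from either compound 1 or compound 2. Among the compounds shown here, the earlier pair compared only two groups that each carry an aromatic ring, whereas 2-hydroxyethyl has no ring, 3 heavy atoms in place of 6, and 1 hydrogen-bond donor in place of 0, and even this exchange on the amide-type nitrogen gives no difference beyond the scatter. No measurement at hand accounts for this result. Still open, from the compounds shown here alone, is whether an amine, a carboxylic acid or a longer chain on this nitrogen would give a number beyond the scatter. Going by these compounds, these compounds are also compared here only in this assay, so how they compare in any other test remains open.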